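The source may hold more compounds than are shown below. What is called first, only, known or untested is meant among the compounds shown, and "the series" means these compounds.

Two members of the series have numbers in an ADME assay on MT4 cells (Homo sapiens) for cytotoxicity, read by MTT assay; a higher number here means that more compound is tolerated, a lower number that less compound is tolerated. Compound 1 `O=C1c2ccccc2C(=O)N1CCOC(=S)N(C(=O)c1ccc(C(F)(F)F)cc1)c1ccc(Cl)cc1` gives 10000 nM. Going by the values given here, compound 2 `O=C1c2ccccc2C(=O)N1CCOC(=S)N(C(=O)c1c(Cl)cccc1Cl)c1ccc(Cl)cc1` gives 20000 nM, the highest of the two numbers, with compound 1 nearest; the single measured step, a 2.0-fold higher number from compound 1 to compound 2 (0.30 log units; within the scatter), lies within the scatter. Compound 3 `Cc1cc(C(=O)N(C(=S)OCCN2C(=O)c3ccccc3C2=O)c2ccc(Cl)cc2)c(C)o1` is the next member, without a measurement yet. It differs from compound 2 at one place: 2,5-dimethylfuran-3-yl in place of 2,6-dichlorophenyl on a carbonyl carbon. Among the compounds with values here, the only step that bears on this change is the earlier exchange of the group on the carbonyl carbon, a 2.0-fold higher number from compound 1 to compound 2 (0.30 log units; within the scatter), which stayed within the scatter, so the series gives no sign that changing this group moves the number beyond the scatter. For compound 3 no step beyond the scatter is therefore expected in this assay. The expected step from the measured neighbour is a 1.3-fold lower number from compound 2 to compound 3 (0.12 log units; within the scatter). The estimate for compound 3 is 15000 nM, with a range from 5000 nM to 50000 nM.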

Compound 3, half-maximal cytotoxic concentration: 40000 nM
Beside the measured number, compound 3's estimate is 2.7-fold (0.43 log units) below it, and the stated range covers the measured number.
By their numbers in this assay, from the lowest: compounds 1, 2 and 3 (each within the scatter of the next, the first and the last beyond it).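

In this assay the exchange of 2,6-dichlorophenyl for 2,5-dimethylfuran-3-yl on the carbonyl carbon gives a 2.0-fold higher number from compound 2 to compound 3 (0.30 log units; within the scatter) and so adds a five-membered aromatic ring with a hetero atom without leaving the scatter. Going by these compounds alone, the exchange of 4-(trifluoromethyl)phenyl for the same furan gives a 4.0-fold higher number from compound 1 to compound 3 (0.60 log units; beyond the scatter) and is the only step here beyond the scatter, so the choice of group at this position can move the number, though only modestly so far. Nothing available explains this step.

The compounds shown leave open whether the two methyl groups or the furan ring itself accounts for the step from compound 1, which an unsubstituted furan-3-yl would test. They also leave open whether a cyclohexyl group or an aminomethyl group on this carbonyl carbon would stay within the same range.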